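Sulfonamide series: from biaryl to ethylcarbamoyl on the pyridine

A few compounds are considered here, and "the series" means these few. Any claim that something is new, unique, unknown or untested is made for them only; others in the source may bear on it.

The series builds on an aryl sulfonamide attached to a six-membered aromatic ring with one nitrogen. Compound 1 `COc1ccc(C(N)=O)cc1S(=O)(=O)Nc1cccnc1` carries a carboxamide on the sulfonyl-bearing ring and a plain pyridine; in an assay on isolated protein for inhibition of alkaline phosphatase, tissue-nonspecific isozyme (Homo sapiens) (on this read-out lower numbers stand for stronger inhibition and higher numbers for weaker inhibition), compound 1 gives "not determined" (no result reported). Going by the values given here, compound 3 `COc1ccc(Cl)cc1S(=O)(=O)Nc1cnc2ccccc2c1` is the only member with a number: in this assay compound 3 gives 4510 nM. Compound 2 `COc1ccc(Cl)cc1S(=O)(=O)Nc1cncc(-c2ccc(Cl)cc2)c1` has no number of its own; in this assay compound 2 gives "not determined" (no result reported), and it therefore stands nowhere on the scale shown, only as a structure.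

The step to compound 4 `CCNC(=O)c1cncc(NS(=O)(=O)c2cc(Cl)ccc2OC)c1` is ethylcarbamoyl in place of 4-chlorophenyl on an aromatic carbon. Since compound 2 has no result, no size or direction for this step can be stated from data, and no comparison with the scatter is possible; it is written down as an open step.

Among the compounds with values here, what remains is the single anchor of compound 3. Compound 4 shares the chloro-methoxyphenyl sulfonamide with compound 3 but replaces the fused bicyclic ring with a single ring bearing an ethylcarbamoyl group. On that basis the inhibitory concentration of compound 4 is expected near 8000 nM, with the range 2000 nM to 40000 nM reflecting that only one measured point supports the estimate.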

Compound 4, half-maximal inhibitory concentration: > 20000 nM
Compound 4: a limit, no number; the forecaster's own chance of this, stated with the estimate: 35%; middle value at least 2.5-fold (0.39 log units) away from the limit.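

In this assay compound 4 gives > 20000 nM, which is a limit of the assay and not a number. Compound 2 has no number in the data shown, so no step can be read between compound 2 and compound 4. The compounds shown leave open whether ethylcarbamoyl in place of 4-chlorophenyl strengthens or weakens inhibition.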